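This account rests on a few compounds, and the source may have more. Where it says the series, first, only, none or still open, it means among the compounds named here.

The two compounds measured so far:

compound 1, `CC(=O)c1cccc(Nc2ccnc(SCC(=O)c3ccc(-c4ccccc4)cc3)n2)c1`, gives 41% in a functional assay on MDA-MB-231 cells (Homo sapiens) for inhibition, read by sulforhodamine B assay, with a stated time of 48 h, tested at 10 uM; on this read-out lower numbers stand for less inhibition of growth and higher numbers for more inhibition of growth at the one concentration tested.
compound 2, `CCOC(=O)c1ccc(Nc2ccnc(SCC(=O)c3ccc([N+](=O)[O-])cc3)n2)cc1`, gives 22% in this assay.

Compound 1 stands highest of these two numbers. Its nearest neighbour is compound 2, whose number lies below it by more than the usual scatter of this kind of measurement, so the two are genuinely different. Compound 2, however, differs from compound 1 in more than one place at once, so nothing can be read from that pair about any single change.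

Compound 3, `COc1ccc(C(=O)CSc2nccc(Nc3cccc(C(C)=O)c3)n2)cc1`, has not yet been measured. Set against compound 1, the difference is methoxy in place of phenyl on an aromatic carbon, the change sitting on an aromatic carbon of a six-membered aromatic ring of carbon only. Going by the values given here, no pair of measured compounds differing in one place exists to show how such a swap plays out, so any expectation rests on the picture of compound 1 alone.

In this assay a small step downward from compound 1 is expected, of a size that may stay within the scatter or only just exceed it. The expected step of a number 11 percentage points lower from compound 1 to compound 3 (beyond the scatter) is therefore a modest decrease. For compound 3 the estimated value is 30%, with a range from 12% to 50%.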

Compound 3, percent growth inhibition at one concentration: 27%
Estimate against measurement, compound 3: 3 percentage points above; the range from low to high includes it.
By their numbers in this assay, from the lowest: compounds 2 and 3 (each within the scatter of the next); then compound 1.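

Going by these compounds alone, replacing phenyl with methoxy gives a number 14 percentage points lower from compound 1 to compound 3 (beyond the scatter) in this assay, the first comparison in this set in which only one place changes, and it shows that the read-out responds to the group at this position, para to a large group. The swap removes a six-membered aromatic ring of 6 heavy atoms and brings in 2 heavy atoms with 1 hydrogen-bond acceptor, so ring, size and acceptor all change together, and this single step cannot separate them. Even without the phenyl, compound 3 gives 27%, so some inhibition of growth remains at the one concentration tested, and no measurement at hand explains the drop.

The compounds shown leave open whether the loss comes from removing the ring or from introducing the oxygen, something a methyl group, a longer ethoxy chain or an amine at the same place could help to tell apart. They also leave open whether this swap would give a step of similar size with a different group elsewhere on the molecule.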